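This account rests on a few compounds, and the source may have more. Where it says the series, first, only, none or still open, it means among the compounds named here.

In a functional assay on SGC-7901 cells (Homo sapiens) for inhibition, read by MTT assay, with a stated time of 24 h (a higher number here means a weaker inhibitor, a lower number a stronger inhibitor), compound 2 `CC1(C)[C@H]2CC[C@]1(C)N(Cc1cn(-c3cccc(Cl)c3)nn1)C(=O)C2` gives 510 nM and compound 1 `CC1(C)[C@H]2CC[C@]1(C)N(Cc1cn(-c3ccccc3F)nn1)C(=O)C2` gives 300 nM, so the two cannot be ranked. Compound 3 `Cc1ccc(-n2cc(CN3C(=O)C[C@@H]4CC[C@@]3(C)C4(C)C)nn2)cc1` differs from compound 2 by 4-methylphenyl in place of 3-chlorophenyl on an aromatic nitrogen, in words 4-methylphenyl in place of 3-chlorophenyl on an aromatic nitrogen. For the measured compounds named here, the only measured step at this place is a 1.7-fold higher number from compound 1 to compound 2 (0.23 log units; within the scatter). Going by the values given here, no measured compound carries 4-methylphenyl, so this evidence is thin, and no change beyond the scatter is expected in this assay. The expected step is a 1.3-fold lower number from compound 2 to compound 3 (0.11 log units; within the scatter). Compound 3 is estimated at 400 nM, with an expected range of 150 nM to 1000 nM.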

Compound 3, half-maximal inhibitory concentration: 390 nM
For compound 3 the middle estimate is 1.0-fold (0.01 log units) above the measured one; measured number inside the range.
By their numbers in this assay, from the lowest: compounds 1, 3 and 2 (each within the scatter of the next).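

In this assay the change to 4-methylphenyl on the aromatic nitrogen gives a 1.3-fold lower number from compound 2 to compound 3 (0.12 log units; within the scatter) and also a 1.3-fold higher number from compound 1 to compound 3 (0.11 log units; within the scatter), both within the scatter. The three substituted phenyl groups in compounds 1, 2 and 3, carrying fluorine, chlorine or methyl, therefore cannot be told apart at this position, and a group without halogen fits the same band. No supporting measurement bears on this result. Still open, going by these compounds, is whether a phenyl ring bearing an amine or a carboxylic acid, or a longer chain in place of the phenyl, would give a step beyond the scatter.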